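The source may report more compounds than this note shows. Statements on the series, on what has been measured and on what is new or still open speak of the compounds shown alone.

Compound 1, `CC1(Sc2ccccc2)C(=O)N(c2ccccc2)c2ncccc21`: 0%
Compound 2, `CC1(C)C(=O)N(c2ccccc2Cl)c2ncccc21`: 14%
Compound 3, `CC1(C)C(=O)N(c2ccc(S(C)(=O)=O)cc2)c2ncccc21`: 42%

All three were tested in a functional assay on the whole organism (Pleural cavity) for inhibition, with Rattus norvegicus as the target, at a dose of 25 mg/kg; on this read-out lower numbers stand for less inhibition and higher numbers for more inhibition at the one dose given (going by the name of the read-out). Compound 3 stands at the top of these three numbers; the gap to compound 2 and the still wider gap to compound 1 are both beyond the usual scatter of repeat measurements, so the inhibition of compound 3 in this assay is the highest of the set.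

Compound 4, `COc1ccc(N2C(=O)C(C)(C)c3cccnc32)cc1`, has not yet been measured in this assay. It differs from compound 3 in a single place: methoxy in place of methylsulfonyl on an aromatic carbon. Within the data shown here, no pair of measured compounds shows the effect of this change, so the expectation rests on the value of compound 3 alone. A moderate fall is expected, a number 17 percentage points lower from compound 3 to compound 4 (beyond the scatter), likely beyond the scatter. Compound 4 is therefore estimated at 25%, in a range from 5% to 45%.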

Compound 4, a percentage reported as inhibition, in the whole organism at one dose (the size of the read-out at that dose, not a potency): 63%
The estimate for compound 4 lay 38 percentage points below the measured number; measured number outside the range, above it.
By their numbers in this assay, from the lowest: compound 1; then compound 2; then compound 3; then compound 4.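

Methoxy in place of methylsulfonyl on this aromatic carbon, para to a large group, gives a number 21 percentage points higher from compound 3 to compound 4 (beyond the scatter) in this assay. Among these compounds, this is the first comparison in the set that changes one place only, and it shows that methylsulfonyl is not needed here for inhibition at this dose. No measurement at hand explains the rise.

From the compounds shown here alone, whether an amine, a hydroxyl group or a longer chain such as ethoxy at this same place would give a higher or lower number remains open. So does whether the same change would have a similar effect on compound 1 or compound 2.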